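A few compounds are considered here, and "the series" means these few. Any claim that something is new, unique, unknown or untested is made for them only; others in the source may bear on it.

Compound 1 `Cc1noc(C)c1S(=O)(=O)N1CCC(N2CCC(C)CC2)CC1`; compound 2 `Cc1ccc(S(=O)(=O)N2CCC(N3CCC(C)CC3)CC2)cc1C`.

In a functional assay on DLD-1 cells (Homo sapiens) for antiproliferative activity, read by CellTiter-Glo, with a stated time of 72 h (a lower number here means a stronger inhibitor, a higher number a weaker inhibitor), compound 1 reaches only the limit of the assay, > 5000 nM. Compound 1 thus sits at the limit of > 5000 nM in this assay, at which 1 of the 2 values shown sits. In this assay, among the compounds with values here, compound 2 gives 24 nM, the single number among the two values shown. Within the data shown here, the one measured step, an at least 200-fold lower number from compound 1 to compound 2 (2.31 log units; beyond the scatter), shows that replacing the heteroaryl on the sulfonyl sulfur with the dimethylphenyl mattered greatly.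

Compound 3 `CC1CCN(C2CCN(S(=O)(=O)c3cccnc3F)CC2)CC1` carries 2-fluoropyridin-3-yl in place of 3,4-dimethylphenyl on a sulfonyl sulfur. This returns to a heteroaryl, now with one hetero atom and one acceptor, so a weaker result in this assay is expected, though a smaller step than the measured one: a 13-fold higher number from compound 2 to compound 3 (1.10 log units; beyond the scatter) is the expected step. Compound 3 is estimated at 300 nM, between 60 nM and 2000 nM.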

Compound 3, half-maximal inhibitory concentration: > 5000 nM
Compound 3 ended at the assay's limit (the forecaster's own chance of this, stated with the estimate: 15%); at least 16-fold (1.22 log units) between middle value and limit.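

In this assay, 2-fluoropyridin-3-yl in place of 3,4-dimethylphenyl on the sulfonyl sulfur brings an at least 200-fold higher number from compound 2 to compound 3 (2.31 log units; beyond the scatter); the loss is thus not confined to the 3,5-dimethyl-1,2-oxazol-4-yl. Of the three groups at this place, only the 3,4-dimethylphenyl gives a number rather than a limit. The step between the other two cannot be read, as compound 1 and compound 3 both sit at a limit: the limit of > 5000 nM in this assay, at which 2 of the 3 values shown sit.

From the compounds shown here alone, whether an unsubstituted phenyl or a chlorophenyl keeps a number here stays open. So does whether each methyl of the 3,4-dimethylphenyl is needed.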